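Swapping the benzyl substituent in a trimethoxyphenyl acetamide series

The source may report more compounds than this note shows. Statements on the series, on what has been measured and on what is new or still open speak of the compounds shown alone.

Measured compounds:
compound 1, `COc1ccc(CN(C(=O)CSc2nc3ccccc3s2)c2cc(OC)c(OC)c(OC)c2)cc1[N+](=O)[O-]`, 26500 nM
compound 2, `COc1ccc(CN(C(=O)CSc2nc3c(C)cccc3s2)c2cc(OC)c(OC)c(OC)c2)cc1O`, 12300 nM
compound 3, `COc1ccc(CN(C(=O)CSc2nc3cc(Br)ccc3s2)c2cc(OC)c(OC)c(OC)c2)cc1O`, 8210 nM

In a functional assay on PC-3 cells (Homo sapiens) for antiproliferative activity, read by MTT assay, with a stated time of 48 h (a higher number here means a weaker inhibitor, a lower number a stronger inhibitor), compound 1 gives the highest number of the three, compound 2 the nearest and compound 3 the furthest. Among the measured compounds shown here, the only single-point step recorded, a 1.5-fold lower number from compound 2 to compound 3 (0.18 log units; within the scatter), concerns the group on the sulfur and is within the scatter. Compound 4, `COc1cc(N(Cc2ccc(Br)cc2)C(=O)CSc2nc3ccccc3s2)cc(OC)c1OC`, differs from compound 1 by 4-bromophenyl in place of 4-methoxy-3-nitrophenyl on a saturated chain carbon bound to an amide-type nitrogen. For the measured compounds named here, no measured step covers this change; compounds 2 and 3 carry a different benzyl group and return lower numbers, but they also differ elsewhere, so they only hint that this position can move the number. Compound 4 is therefore expected near 10000 nM, between 3000 nM and 35000 nM, a step of a 2.7-fold lower number from compound 1 to compound 4 (0.42 log units; beyond the scatter) that is uncertain in size.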

Compound 4, half-maximal inhibitory concentration: > 80000 nM
Compound 4 was reported as a limit; the forecaster's own chance of this, stated with the estimate: 10%; middle value at least 8.0-fold (0.90 log units) from the limit.
By their numbers in this assay, from the lowest: compounds 3 and 2 (each within the scatter of the next); then compound 1. At a limit, above all of these: compound 4.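

In this assay, among the compounds shown here, the change from 4-methoxy-3-nitrobenzyl to 4-bromobenzyl gives an at least 3.0-fold higher number from compound 1 to compound 4 (0.47 log units; beyond the scatter), the first step that can be read at this position, showing that this group alone can shift the number upward. Compound 4 is reported only as a limit, > 80000 nM. The step therefore has a lower bound but no fixed size: the limit of > 80000 nM in this assay, at which 1 of the 4 values shown sits.

The compounds shown leave open which part of 4-methoxy-3-nitrophenyl carries the difference, the nitro group or the methoxy group, and whether the bromine plays any part. Also open, on these data alone, is where an aminobenzyl or a carboxybenzyl group in this place would fall.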